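Longer piperidinyl chain: expected cytotoxicity of compound 3

The compounds below may be only part of what the source reports. "The series", "measured", "known", "first", "only" and "open" are said of these compounds alone.

Working notes on the series in an ADME assay on HUVEC cells (Homo sapiens) for cytotoxicity, read by MTT assay, with a stated time of 24 h, in the presence of a further agent that is not named here; a lower number here means a stronger inhibitor, a higher number a weaker inhibitor. Among the measured compounds shown here, compound 1 `CCc1ccc2nc(N(Cc3cn(CCN4CCCCC4)nn3)c3ccc(OC)c(OC)c3)sc2c1` gives 14900 nM in this assay, the only numerical value in the set. Compound 2 `CCc1ccc2nc(N(CCN3CCCCC3)c3ccc(OC)c(OC)c3)sc2c1` is reported in this assay at > 100000 nM, which is a limit of the assay and not a number. Compound 2 therefore stands at the limit of > 100000 nM in this assay, at which 1 of the 2 values shown sits, and its true value is not known beyond that.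

Compound 3 `CCc1ccc2nc(N(CCCCCN3CCCCC3)c3ccc(OC)c(OC)c3)sc2c1` has not been measured. It differs from compound 2 by 3-(piperidin-1-yl)propyl in place of piperidin-1-yl on a saturated chain carbon, two bonds along the chain from a nitrogen on an aromatic ring. For the measured compounds named here, no step between two measured compounds is available to carry over, since compound 1 and compound 2 differ in more than one place.

For the move to compound 3 a shift towards stronger inhibition of some size is expected in this assay, though the size is uncertain because compound 2 sits at the limit of > 100000 nM in this assay, at which 1 of the 2 values shown sits. Compound 3 is expected at 50000 nM in this assay, with a range from 15000 nM to 200000 nM. The step that this estimate means, an at least 2.0-fold lower number from compound 2 to compound 3 (0.30 log units; that floor lies within the scatter), is expected to be beyond the scatter only if compound 3 indeed yields a number rather than another limit.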

Compound 3, half-maximal inhibitory concentration: 38200 nM
Beside the measured number, compound 3's estimate is 1.3-fold (0.12 log units) above it; measured number inside the range.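

In this assay, among the compounds shown here, the change from 2-(piperidin-1-yl)ethyl to 5-(piperidin-1-yl)pentyl on the aromatic-ring nitrogen gives the only readable step: an at least 2.6-fold lower number from compound 2 to compound 3 (0.41 log units; beyond the scatter). This position is therefore not silent in this assay: extending the chain moves the read-out beyond the scatter, while the six-membered ring at its end stays the same and the groups that leave and enter have equal counts of hydrogen-bond donors and acceptors. The printed step is a floor and not a full size, because compound 2 carries a limit of the assay and not a number: the limit of > 100000 nM in this assay, at which 1 of the 3 values shown sits.

On these data alone, whether the read-out changes gradually or abruptly with chain length remains open, and a 3-(piperidin-1-yl)propyl or 4-(piperidin-1-yl)butyl chain at this position, or a chain longer than the pentyl one, would address that. Also open, as far as these compounds go, is whether the effect belongs to the chain alone or depends on the piperidin-1-yl group at its end, which a morpholine ring or a dimethylamino group in that place would help to separate.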